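Moving the fluorine across the stilbene arm

The source may hold more compounds than are shown below. What is called first, only, known or untested is meant among the compounds shown, and "the series" means these compounds.

Measured compounds:
- compound 1, `COC(=O)/C=C/c1cccc(N(Cc2ccc(/C=C/c3ccc(F)cc3)cc2)C(=O)NC(C)C)c1`: 348 nM
- compound 2, `COC(=O)/C=C/c1cccc(N(Cc2ccc(-c3ccc(N(C)C)cc3)cc2)C(=O)NC(C)C)c1`: 162 nM

Among the compounds with values here, in an assay on isolated protein with Bile acid receptor (Homo sapiens) as the target (a higher number here means that more compound is needed for the effect, a lower number that less compound is needed), compound 2 gives the lowest of the two numbers so far; its nearest neighbour is compound 1, which gives 348 nM in this assay. Within the data shown here, the only step known is a 2.1-fold lower number from compound 1 to compound 2 (0.33 log units; beyond the scatter), a modest gain when the 4-(dimethylamino)phenyl took the place of the 2-(4-fluorophenyl)ethenyl group.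

Compound 3, `COC(=O)/C=C/c1cccc(N(Cc2ccc(/C=C/c3cccc(F)c3)cc2)C(=O)NC(C)C)c1`, carries the change (2-(3-fluorophenyl)ethenyl in place of 4-(dimethylamino)phenyl on an aromatic carbon). Its new group sits on an aromatic carbon of a six-membered aromatic ring of carbon only, para to a large group. Among the measured compounds shown here, this largely undoes the single measured step: the ethenyl-linked fluorophenyl returns, only with the fluorine moved from the 4-position to the 3-position. Since that earlier step was modest, the reverse is expected to be of similar size, and the number is expected to rise, roughly a 1.9-fold higher number from compound 2 to compound 3 (0.27 log units; within the scatter). Compound 3 is therefore estimated at 300 nM in this assay, with a range of 120 nM to 750 nM.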

Compound 3, half-maximal effective concentration: 467 nM
The estimate for compound 3 lay 1.6-fold (0.19 log units) below the measured number, and the stated range covers the measured number.
By their numbers in this assay, from the lowest: compound 2; then compounds 1 and 3 (each within the scatter of the next).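

In this assay, moving the fluorine from the 4-position to the 3-position of the ethenyl-linked ring gives a 1.3-fold higher number from compound 1 to compound 3 (0.13 log units; within the scatter) and so leaves the two placements unseparated in this assay. Set against the 4-(dimethylamino)phenyl group, the 2-(3-fluorophenyl)ethenyl group gives a 2.9-fold higher number from compound 2 to compound 3 (0.46 log units; beyond the scatter) and thus a second case, after compound 1, in which a fluorinated ethenyl arm at this para position stands above compound 2 by more than the scatter. Nothing among the data shown accounts for either step.

Compound 2 differs from the two fluorinated compounds both in the ethenyl link, which it lacks, and in what its outer ring carries, so these compounds cannot show which of the two differences matters for the gap. A dimethylamino group on the ethenyl-linked ring, or a fluorine on a phenyl ring joined without the ethenyl link, would pull those two apart, and a 2-(2-fluorophenyl)ethenyl group would complete the set of fluorine placements on that ring.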